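Lengthening the alkyl chain of compound 2

This account rests on a few compounds, and the source may have more. Where it says the series, first, only, none or still open, it means among the compounds named here.

Measured so far in a functional assay on MDA-MB-231 cells (Homo sapiens) for antiproliferative activity, with a stated time of 4 days; a lower number here means a stronger inhibitor, a higher number a weaker inhibitor
- compound 1 `COc1ccc(-c2[nH]c3cc(F)ccc3c2C=O)cc1` gives 59 nM
- compound 2 `CCCCc1ccc2[nH]c(-c3ccc(OC)cc3)c(C=O)c2c1` gives 6.7 nM

Compound 2 holds the lower of the two numbers, and its gap to compound 1 lies beyond the scatter. These two compounds are not related by a single change, so their gap says nothing about the chain alone. Compound 3 `CCCCCCc1ccc2[nH]c(-c3ccc(OC)cc3)c(C=O)c2c1` departs from compound 2 in one place: ethyl in place of hydrogen on a saturated chain carbon, four bonds along the chain from an aromatic carbon. Among the measured compounds shown here, no measured pair yet isolates a change of this kind, so the expectation in this assay is loose. The estimated 1.8-fold higher number from compound 2 to compound 3 (0.25 log units; within the scatter) is a small rise toward weaker inhibition, within the scatter. Compound 3 is expected at 12 nM (estimated range 4 nM to 40 nM).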

Compound 3, half-maximal inhibitory concentration: 7.4 nM
The estimate for compound 3 lay 1.6-fold (0.21 log units) above the measured number; the measured number falls inside the stated range.
By their numbers in this assay, from the lowest: compounds 2 and 3 (each within the scatter of the next); then compound 1.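

In this assay, among the compounds shown here, the step of a 1.1-fold higher number from compound 2 to compound 3 (0.04 log units; within the scatter) is the first measured pair that isolates a change on this chain, and it lies within the scatter. Ethyl in place of hydrogen on a saturated chain carbon, four bonds along the chain from an aromatic carbon, is therefore accommodated here without a step beyond the scatter, so compound 2 and compound 3 cannot be told apart at this position. No measurement of any property of these compounds bears on the result, and no cause can be assigned to it.

Going by these compounds, a single step sets no trend along the chain, so whether a longer chain such as octyl or a shorter one such as methyl would stay within the scatter of compound 2 remains open. Also open, on these data alone, is how an amine or a carboxylic acid in place of the chain would read in this assay on this shared core.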